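The compounds below may be only part of what the source reports. "The series", "measured", "known", "first", "only" and "open" are said of these compounds alone.

Compound 1 `N/C(=N\NC(=S)N1CCOCC1)c1ccccn1` and compound 2 `Cc1cccc(/C(N)=N/NC(=S)N2CCSCC2)n1` have both been tested in a functional assay on HeLa cells (Homo sapiens) for cytotoxicity, read by MTT assay, with a stated time of 72 h, tested at 1 uM; on this read-out lower numbers stand for less inhibition of growth and higher numbers for more inhibition of growth at the one concentration tested. In this assay compound 1 gives 12.7%, while compound 2 gives 46.5%, the higher of the two numbers by a gap beyond the usual scatter. Compound 3 `Cc1cccc(/C(N)=N/NC(=S)N2CCOCC2)n1` has not yet been measured. It differs from compound 2 in one place: morpholin-4-yl in place of thiomorpholin-4-yl on a thiocarbonyl carbon. Going by the values given here, no measured pair isolates this change; the only hint is compound 1, which also carries the morpholin-4-yl group and gives only 12.7%. For compound 3 a drop is therefore expected, a number 21.5 percentage points lower from compound 2 to compound 3 (beyond the scatter). Compound 3 is estimated at 25%, within a range from 8% to 45%.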

Compound 3, percent growth inhibition at one concentration: 25.7%
Estimate against measurement, compound 3: 0.7 percentage points below, within the range that was stated.
By their numbers in this assay, from the lowest: compound 1; then compound 3; then compound 2.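

With nothing else altered, the change to morpholin-4-yl on the thiocarbonyl carbon gives a number 20.8 percentage points lower from compound 2 to compound 3 (beyond the scatter) in this assay, so this ring swap alone lowers growth inhibition. Methyl in place of hydrogen on an aromatic carbon gives a number 13 percentage points higher from compound 1 to compound 3 (beyond the scatter) as a separate single change, so the morpholin-4-yl compounds do not all sit equally low. No supporting data explain either step. Piperidin-1-yl or 4-methylpiperazin-1-yl on the thiocarbonyl carbon could show how other rings compare. On these data alone, an ethyl or chloro group in place of the methyl remains open too.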